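The source may hold more compounds than are shown below. What is called first, only, known or untested is meant among the compounds shown, and "the series" means these compounds.

Three amides sharing one core have been measured in a functional assay on A549 cells (Homo sapiens) for antiproliferative activity, read by MTT assay, with a stated time of 72 h; on this read-out higher numbers stand for weaker inhibition and lower numbers for stronger inhibition. Compound 1 (`CCC/C=C/C(=O)Nc1cccc(Oc2nc(Nc3ccn(C)n3)nc3c2CSCC3)c1`) gives 8190 nM, compound 2 (`CC(C)=CC(=O)Nc1cccc(Oc2nc(Nc3ccn(C)n3)nc3c2CSCC3)c1`) gives 44200 nM, and compound 3 (`CC(C)/C=C/C(=O)Nc1cccc(Oc2nc(Nc3ccn(C)n3)nc3c2CSCC3)c1`) gives 33500 nM. Compound 3 therefore stands level with compound 2, with a 1.3-fold lower number from compound 2 to compound 3 (0.12 log units; within the scatter), and both sit at the weak end of the series. Compound 1 stands apart, with a 4.1-fold higher number from compound 1 to compound 3 (0.61 log units; beyond the scatter).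

Compound 4 (`C=C(F)C(=O)Nc1cccc(Oc2nc(Nc3ccn(C)n3)nc3c2CSCC3)c1`) keeps the core and has 1-fluoroethenyl in place of 3-methylbut-1-en-1-yl on a carbonyl carbon. Within the data shown here, no measured compound carries 1-fluoroethenyl, so the evidence is indirect. The nearest guides are the other changes at this carbonyl carbon, namely a 5.4-fold higher number from compound 1 to compound 2 (0.73 log units; beyond the scatter) and the modest step to compound 3 given above. These show that this place can move the number in this assay, but they do not show how the entering group will behave.

A modest step towards a lower number is expected, and the expected step is a 4.8-fold lower number from compound 3 to compound 4 (0.68 log units; beyond the scatter). For compound 4 the estimated value is 7000 nM, with an expected range from 1500 nM to 30000 nM.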

Compound 4, half-maximal inhibitory concentration: > 50000 nM
Compound 4: a limit, no number (the forecaster's own chance of this, stated with the estimate: 5%); middle value at least 7.1-fold (0.85 log units) away from the limit.
By their numbers in this assay, from the lowest: compound 1; then compounds 3 and 2 (each within the scatter of the next). At a limit, above all of these: compound 4.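

In this assay compound 4 stands at a limit and not at a number: the limit of > 50000 nM in this assay, at which 1 of the 4 values shown sits. Against the two branched compounds, the steps are an at least 1.4-fold higher number from compound 3 to compound 4 (0.17 log units; that floor lies within the scatter) and an at least 1.1-fold higher number from compound 2 to compound 4 (0.05 log units; that floor lies within the scatter), so the result does not separate compound 4 from either of them. Only an at least 6.1-fold higher number from compound 1 to compound 4 (0.78 log units; beyond the scatter) clears the scatter, which shows that 1-fluoroethenyl on a carbonyl carbon, with its 3 heavy atoms, does not recover the lower number of compound 1, and that pent-1-en-1-yl remains the one group shown here that stands apart from the others.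

The compounds shown leave open how a plain ethenyl group or a longer straight chain would read at this carbonyl carbon. They also leave open how far the true value of compound 4 lies from its limit.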